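Swapping a dimethylphenyl amide for a dimethylthiazolyl amide

The source may hold more compounds than are shown below. What is called first, only, known or untested is meant among the compounds shown, and "the series" means these compounds.

Measured so far:
compound 1 `Cc1cc(C)cc(NC(=O)COc2cc(C)nc3ccc(OCc4ccccc4)cc23)c1` gives 7.03;
compound 2 `COc1ccc2nc(C)cc(OCC(=O)Nc3cc(C)ccc3C)c2c1` gives 5.05;
compound 3 `COc1ccc2nc(C)cc(OCC(=O)Nc3cc(OC)c(Cl)cc3OC)c2c1` gives 5.8.

In a physicochemical assay for lipophilicity, read by HPLC, in phosphate buffer, measured as chromatographic lipophilicity, at pH 7.4 (a lower number here means a more polar compound, a higher number a more lipophilic compound), compound 2 stands lowest of the three numbers. Compound 3 sits above it by a margin beyond the scatter, and compound 1 lies higher still, also beyond the scatter. The new compound 4 `COc1ccc2nc(C)cc(OCC(=O)Nc3nc(C)c(C)s3)c2c1` differs from compound 2 in one place: 4,5-dimethyl-1,3-thiazol-2-yl in place of 2,5-dimethylphenyl on an amide-type nitrogen. No step between measured compounds shows what this change does, so no shown step can be cited as a cause. The account expects a moderate step downward, beyond the scatter, from compound 2 to compound 4, which is a number 0.65 log units lower from compound 2 to compound 4 (beyond the scatter). For compound 4 the estimate in this assay is 4.4, with a range from 3.7 to 5.1.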

Compound 4, distribution coefficient: 4.24
Beside the measured number, compound 4's estimate is 0.16 log units above it, within the range that was stated.
By their numbers in this assay, from the lowest: compound 4; then compound 2; then compound 3; then compound 1.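

In this assay, going by these compounds alone, the change at this position can now be read directly for the first time: the step runs a number 0.81 log units lower from compound 2 to compound 4 (beyond the scatter) with the shared core held constant, a modest move beyond the scatter. It shows that 4,5-dimethyl-1,3-thiazol-2-yl in place of 2,5-dimethylphenyl on the amide-type nitrogen is enough by itself to shift this read-out. Nothing given here explains the shift.

The compounds shown leave open whether the ring or its two methyl groups carry the step. From the compounds shown here alone, how a pyridin-2-yl group would read on this nitrogen also remains open.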